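Swapping the dichlorophenyl on a hydrazone for dimethoxyphenyl

The source may hold more compounds than are shown below. What is called first, only, known or untested is meant among the compounds shown, and "the series" means these compounds.

Measured compounds:
compound 1, `CN(C)CCn1cnnc1-c1cc(Oc2ccc(NC(=O)N/N=C/c3c(Cl)cccc3Cl)cc2F)ccn1`, gives 160 nM;
compound 2, `CN(C)CCn1cnnc1-c1cc(Oc2ccc(NC(=O)N/N=C/c3cc(C(C)(C)C)cc(C(C)(C)C)c3O)cc2F)ccn1`, gives 3300 nM.

In a functional assay on MKN-45 cells (Homo sapiens) for cytotoxicity, read by MTT assay, with a stated time of 72 h (on this read-out higher numbers stand for weaker inhibition and lower numbers for stronger inhibition), compound 1 holds the lower of the two numbers, with compound 2 standing well apart. Compound 3, `COc1ccc(OC)c(/C=N/NC(=O)Nc2ccc(Oc3ccnc(-c4nncn4CCN(C)C)c3)c(F)c2)c1`, differs from compound 1 in one place: 2,5-dimethoxyphenyl in place of 2,6-dichlorophenyl on a carbon with a double bond to nitrogen. For the measured compounds named here, no step of this kind has been measured. With compound 2 showing 3300 nM after a different change at the same place, a move toward weaker inhibition is expected, though of modest size. Compound 3 is expected to give 500 nM, between 150 nM and 2000 nM. That estimate means a step of a 3.1-fold higher number from compound 1 to compound 3 (0.49 log units; beyond the scatter).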

Compound 3, half-maximal inhibitory concentration: 1510 nM
Compound 3: the middle estimate sits 3.0-fold (0.48 log units) below what was measured; the measured number falls inside the stated range.
By their numbers in this assay, from the lowest: compound 1; then compound 3; then compound 2.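

In this assay, placing 2,5-dimethoxyphenyl in place of 2,6-dichlorophenyl on a carbon with a double bond to nitrogen gives a 9.4-fold higher number from compound 1 to compound 3 (0.97 log units; beyond the scatter). With the rest of the molecule unchanged, this shows that the aryl group at this position alone moves the number beyond the scatter, and that the dimethoxy group does not match the dichloro group here. No measurement shown here accounts for this step. As far as these compounds go, whether the chlorine atoms, the methoxy groups or their placement drive the difference remains open. So does what a single chlorine or a dimethylamino group on this phenyl ring would give.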